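Cytotoxicity notes: sulfonamide in place of butylamine

The source may hold more compounds than are shown below. What is called first, only, known or untested is meant among the compounds shown, and "the series" means these compounds.

Compound 3 `CCCCNc1cccc(N2C[C@@H](c3ccc(OC)c(OC4CCCC4)c3)CC2=O)c1` is, in a functional assay on HEK293 cells (Homo sapiens) for cytotoxicity (a higher number here means that more compound is tolerated, a lower number that less compound is tolerated), reported only as a limit, > 10000 nM. Compound 1 `COc1ccc([C@H]2CC(=O)N(c3ccccc3)C2)cc1OC1CCCC1` in this assay likewise gives a limit, > 10000 nM. Compound 2 `COc1ccc([C@H]2CC(=O)N(c3cccc(S(C)(=O)=O)c3)C2)cc1OC1CCCC1` also sits at a limit, > 10000 nM. The three measured steps, a step that the two limits leave unreadable from compound 1 to compound 2, a step that the two limits leave unreadable from compound 1 to compound 3 and a step that the two limits leave unreadable from compound 2 to compound 3, are thus all of unreadable size, which follows from the limit of > 10000 nM in this assay, at which 3 of the 3 values shown sit.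

Compound 4 `COc1ccc([C@H]2CC(=O)N(c3cccc(NS(=O)(=O)c4cccc(Cl)c4)c3)C2)cc1OC1CCCC1` differs from compound 3 by (3-chlorophenyl)sulfonyl in place of butyl on a nitrogen on an aromatic ring. Among the measured compounds shown here, none of the measured steps alters this nitrogen on the aromatic ring; what they do show is that exchanging hydrogen, methylsulfonyl and butylamino on the aromatic carbon never brought cytotoxicity into the measurable window, so they set no direction for the present change. The expected step is a step that the limit leaves unreadable from compound 3 to compound 4, meaning nothing beyond the scatter is anticipated. Compound 4 is estimated at 15000 nM, within a range of 5000 nM to 40000 nM, and will most likely again be reported only as a limit.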

Compound 4, half-maximal cytotoxic concentration: > 10000 nM
Compound 4: only a limit was reported; the forecaster's own chance of this, stated with the estimate: 80%; the middle value does not contradict the limit.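

In this assay compound 4 gives > 10000 nM, which is a limit. The steps to compound 4 from compound 1, compound 2 and compound 3 therefore cannot be read: the limit of > 10000 nM in this assay, at which 4 of the 4 values shown sit. The compounds shown leave open at what concentration any of them becomes cytotoxic.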